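The source may hold more compounds than are shown below. What is called first, only, known or untested is meant among the compounds shown, and "the series" means these compounds.

Measured in a functional assay on HepG2 cells (Homo sapiens) for cytotoxicity, read by MTT assay, with a stated time of 24 h; a higher number here means a weaker inhibitor, a lower number a stronger inhibitor:
- compound 1 `CN1C/C(=C\c2ccncc2)C(=O)/C(=C/c2ccccc2C(F)(F)F)C1`: 3300 nM
- compound 2 `O=C1/C(=C/c2ccncc2)CN(S(=O)(=O)c2ccccc2)C/C1=C\c1ccccc1F`: 5800 nM
- compound 3 `O=C1/C(=C/c2ccncc2)CNC/C1=C\c1ccccc1C(F)(F)F`: 6130 nM

Compound 3, at 6130 nM, lies within the scatter of the other two compounds, so it holds no distinct rank among them. Compound 4 `O=C1/C(=C/c2ccncc2)CN(S(=O)(=O)c2ccccc2)C/C1=C\c1ccccc1C(F)(F)F` differs from compound 3 in one place, with phenylsulfonyl in place of hydrogen on an amine nitrogen in a ring.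

Among the compounds with values here, only one measured step involves that nitrogen, a 1.9-fold higher number from compound 1 to compound 3 (0.27 log units; within the scatter). It exchanges methyl rather than phenylsulfonyl, so it is only a loose guide. Within the data shown here, no measured pair compares phenylsulfonyl with hydrogen directly. The closest evidence is compound 2, which carries phenylsulfonyl on that nitrogen and gives 5800 nM, although its other phenyl ring has fluorine instead of trifluoromethyl. On that value, no change beyond the scatter is expected in this assay. The expected step is a 1.2-fold lower number from compound 3 to compound 4 (0.09 log units; within the scatter). For compound 4, the estimate is 5000 nM, with an expected range from 2200 nM to 11000 nM.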

Compound 4, half-maximal inhibitory concentration: 7020 nM
Compound 4: the middle estimate sits 1.4-fold (0.15 log units) below what was measured; the measured number falls inside the stated range.
By their numbers in this assay, from the lowest: compounds 1, 2, 3 and 4 (each within the scatter of the next, the first and the last beyond it).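

Direct comparison on the ring nitrogen shows that, in this assay, phenylsulfonyl in place of hydrogen gives a 1.1-fold higher number from compound 3 to compound 4 (0.06 log units; within the scatter), so adding this much larger group leaves the number within the scatter. With phenylsulfonyl on that nitrogen, trifluoromethyl in place of fluoro on the aromatic carbon gives a 1.2-fold higher number from compound 2 to compound 4 (0.08 log units; within the scatter), so this swap also shows no clear effect. Within the data shown here, only phenylsulfonyl in place of methyl on the nitrogen gives a 2.1-fold higher number from compound 1 to compound 4 (0.33 log units; beyond the scatter), a modest step just beyond the scatter, which makes methyl and phenylsulfonyl the only pair on this nitrogen that can be told apart.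

No measurement among these compounds bears on what lies behind these small steps. On these data alone, it remains open whether an acetyl group or a longer alkyl chain on the ring nitrogen would move the number further.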